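The source may hold more compounds than are shown below. What is called first, only, known or untested is meant among the compounds shown, and "the series" means these compounds.

Measured compounds:
- compound 1, `Cc1cccc(Nc2nc3nonc3nc2Nc2cccc(C)c2)c1`: 2100 nM
- compound 2, `Fc1ccccc1Nc1nc2nonc2nc1NC1CCCCC1`: 13400 nM
- compound 3, `Fc1ccc(Nc2nc3nonc3nc2Nc2ccccc2F)c(F)c1`: 300 nM

All three were tested in an assay on mitochondria from L6 cells (Rattus norvegicus) for activation, with a stated time of 90 min; a higher number here means that more compound is needed for the effect, a lower number that less compound is needed. Compound 3 gives the lowest number of the three; compound 1 gives a higher number, and compound 2 gives a higher number still, with both gaps beyond the scatter. Within the data shown here, the one single-point step among them is a 45-fold lower number from compound 2 to compound 3 (1.65 log units; beyond the scatter), which shows that a flat aromatic group on this nitrogen is far more favourable than a saturated ring.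

Compound 4, `CCOc1cccc(Nc2nc3nonc3nc2Nc2ccccc2F)c1`, has not been measured. It differs from compound 3 in one place: 3-ethoxyphenyl in place of 2,4-difluorophenyl on a nitrogen on an aromatic ring. Here an aromatic ring is kept, so the large loss seen on going to cyclohexyl should not recur. Among the measured compounds shown here, still, the only measured aryl-to-aryl comparison is indirect: compound 1 and compound 3 differ in two places, and compound 1 sits clearly higher. For the measured compounds named here, with no direct step for swapping one aromatic group for another, a modest rise is the most that can be expected, with this assay likely to give a step of a 3.0-fold higher number from compound 3 to compound 4 (0.48 log units; beyond the scatter). Compound 4 is therefore estimated at 900 nM, within a range from 250 nM to 3500 nM.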

Compound 4, half-maximal effective concentration: 2200 nM
Compound 4: middle estimate off by 2.4-fold (0.39 log units), on the low side; measured number inside the range.
By their numbers in this assay, from the lowest: compound 3; then compounds 1 and 4 (each within the scatter of the next); then compound 2.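

In this assay this nitrogen separates one aromatic group from another: 3-ethoxyphenyl in place of 2,4-difluorophenyl gives a 7.3-fold higher number from compound 3 to compound 4 (0.87 log units; beyond the scatter) and so an aromatic ring alone does not keep the number low. Compared with cyclohexyl, 3-ethoxyphenyl still helps, with a 6.1-fold lower number from compound 2 to compound 4 (0.78 log units; beyond the scatter) against a 45-fold lower number from compound 2 to compound 3 (1.65 log units; beyond the scatter) for 2,4-difluorophenyl, so the size of the gain depends on which aromatic group is attached. No measurement shown explains why these two aromatic groups differ.

The effects of the fluorines and the ethoxy group cannot be separated here, since the two groups differ in both at once. As far as these compounds go, it also remains open how a plain phenyl, or a phenyl carrying an amine or a carboxylic acid, would behave on this nitrogen.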